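The compounds below may be only part of what the source reports. "The series", "measured", "known", "first", "only" and "open" are said of these compounds alone.

In a functional assay on A549 cells (Homo sapiens) for antiproliferative activity, read by MTT assay, with a stated time of 48 h (a lower number here means a stronger inhibitor, a higher number a weaker inhibitor), compound 1 (`Cc1ccc2nc(NC(c3cn(-c4ccccc4)nc3-c3cccc(Cl)c3)c3c(O)ccc4ccccc34)sc2c1`) gives 45400 nM and compound 2 (`Cc1ccc(-c2nn(-c3ccccc3)cc2C(Nc2nc3cc(C)c(C)cc3s2)c2c(O)ccc3ccccc23)cc1`) gives 31200 nM while compound 3 (`COc1ccc(-c2nn(-c3ccccc3)cc2C(Nc2nc3ccccc3s2)c2c(O)ccc3ccccc23)cc1`) gives 26200 nM as its result. These three numbers all lie within the usual scatter of one another, so compound 3 cannot be told apart from compound 1 or compound 2 on these data.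

Compound 4 (`Cc1ccc(-c2nn(-c3ccccc3)cc2C(Nc2nc3ccccc3s2)c2c(O)ccc3ccccc23)cc1`) is the next compound to follow. It matches compound 3 except for methyl in place of methoxy on an aromatic carbon so that 4-methoxyphenyl becomes 4-methylphenyl. This carbon belongs to a six-membered aromatic ring of carbon only and sits para to a large group.

Within the data shown here, no two measured compounds differ in just one place, so the data offer no direct reading of this swap. Compound 2 also carries the 4-methylphenyl group and its 31200 nM sits within the scatter of the number for compound 3. A shift beyond the scatter in this assay is therefore not expected in either direction. The expected change is a 1.1-fold higher number from compound 3 to compound 4 (0.06 log units; within the scatter) and it should stay within the scatter. For compound 4 the estimated value is 30000 nM with the expected range running from 15000 nM to 60000 nM at its two ends.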

Compound 4, half-maximal inhibitory concentration: 57400 nM
For compound 4 the middle estimate is 1.9-fold (0.28 log units) below the measured one; the measured number falls inside the stated range.
By their numbers in this assay, from the lowest: compounds 3, 2, 1 and 4 (each within the scatter of the next, the first and the last beyond it).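

In this assay, among these compounds, the change from 4-methoxyphenyl to 4-methylphenyl gives a 2.2-fold higher number from compound 3 to compound 4 (0.34 log units; beyond the scatter), which is the first reading of a single change at this aromatic carbon, para to a large group, and it shows that the two groups can be told apart here, though only by a modest margin. The other new comparison concerns a different part of the molecule: going from 5,6-dimethyl-1,3-benzothiazol-2-yl to 1,3-benzothiazol-2-yl on the amine nitrogen gives a 1.8-fold higher number from compound 2 to compound 4 (0.26 log units; within the scatter), so with 4-methylphenyl in place, this change cannot be separated from ordinary assay variation. No measurement is available that explains why methoxy and methyl differ at this position.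

This single pair cannot show whether the methoxy-to-methyl step would be of similar size on a different benzothiazole, such as the 5,6-dimethyl-1,3-benzothiazol-2-yl compounds. It also leaves open how other groups on the same carbon, such as a hydroxyl, an amine or a carboxylic acid, would compare with methoxy and methyl.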